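The compounds below may be only part of what the source reports. "The series", "measured", "known", "first", "only" and "open" are said of these compounds alone.

Of the compounds shown here, two have been measured so far. Compound 1 `COC(=O)C[C@H](NC(=O)OC(C)(C)C)C(=O)N(Cc1ccc(F)cc1)C1(C(=O)NCc2ccccc2)CCN(Cc2ccccc2)CC1` is the larger of the two. In an ADME assay on MDCK cells (Canis lupus familiaris) for cytotoxicity, read by microscopy, with a stated time of 72 h (a lower number here means that less compound is tolerated, a higher number that more compound is tolerated), compound 1 gives > 100000 nM, which is a limit of the assay rather than a number, so compound 1 stands only at a limit (the limit of > 100000 nM in this assay, at which 1 of the 2 values shown sits). Compound 2 `COC(=O)C[C@H](NC(=O)OC(C)(C)C)C(=O)N(Cc1ccc(F)cc1)C(C)(C)C(=O)NCc1ccccc1` is the other measured compound. In this assay compound 2 gives 20000 nM. The two measured compounds differ in more than one place, so no single change has yet been followed.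

Compound 3 `COC(=O)C[C@H](NC(=O)OC(C)(C)C)C(=O)N(Cc1ccc(F)cc1)C1(C(=O)NCc2ccccc2)CCN(C)CC1` is compound 1 with one change: hydrogen in place of phenyl on a saturated chain carbon bound to an amine nitrogen in a ring. Among the compounds with values here, with no comparable step in hand, the step from compound 1 to compound 3 is expected to be a number no higher from compound 1 to compound 3 (the limit leaves the size open), that is, nothing clearly beyond the scatter in either direction. Compound 3 is therefore estimated at 100000 nM, with a range from 30000 nM to 300000 nM, and this assay may again report only a limit for compound 3.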

Compound 3, minimum cytotoxic concentration: 17000 nM
Compound 3: the middle estimate sits 5.9-fold (0.77 log units) above what was measured, and the stated range ends above it.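

Within the data shown here, the first change that can be followed in this assay shows that this position matters: hydrogen in place of phenyl, on a saturated chain carbon bound to an amine nitrogen in a ring, gives an at least 5.8-fold lower number from compound 1 to compound 3 (0.76 log units; beyond the scatter). Read one bond further out, this is benzyl to methyl, and on this core less compound is tolerated with methyl than with benzyl. The value for compound 1 is a limit of the assay, so the step has a smallest size but no known full size: the limit of > 100000 nM in this assay, at which 1 of the 3 values shown sits.

The compounds shown hold only benzyl and methyl at this place, so they cannot tell whether the phenyl ring itself is needed for the higher number. On these data alone, whether a longer chain such as ethyl, or a pyridylmethyl group, would stay closer to compound 3 or to compound 1 remains open.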